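A few compounds are considered here, and "the series" means these few. Any claim that something is new, unique, unknown or untested is made for them only; others in the source may bear on it.

Compound 1 `COc1ccccc1-c1nnc(SCCn2c([N+](=O)[O-])cnc2C)o1` is the weaker-numbered of the two compounds measured in a functional assay on SGC-7901 cells (Homo sapiens) for cytotoxicity, read by MTT assay, with a stated time of 48 h (a lower number here means a stronger inhibitor, a higher number a weaker inhibitor), where compound 1 gives 30500 nM. Its nearest neighbour is compound 2 `Cc1ccc(-c2nnc(SCCn3c([N+](=O)[O-])cnc3C)o2)c(O)c1`, which in this assay gives 36700 nM; the step of a 1.2-fold higher number from compound 1 to compound 2 (0.08 log units; within the scatter) lies within the scatter. Compound 3 `Cc1ncc([N+](=O)[O-])n1CCSc1nnc(-c2ccc(N)nc2)o1` differs from compound 1 by 6-aminopyridin-3-yl in place of 2-methoxyphenyl on an aromatic carbon. Going by the values given here, no measured step exchanges this group for an aminopyridinyl ring, so only the single small step from compound 1 to compound 2 offers any guide, and it shows no change beyond the scatter. Compound 3 is therefore expected to stay near compound 1, at an estimated 32000 nM (range 10000 nM to 100000 nM), a step of a 1.0-fold higher number from compound 1 to compound 3 (0.02 log units; within the scatter) that is expected to be small.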

Compound 3, half-maximal inhibitory concentration: 30900 nM
Estimate against measurement, compound 3: 1.0-fold (0.02 log units) above; low and high end bracket the measured number.
By their numbers in this assay, from the lowest: compounds 1, 3 and 2 (each within the scatter of the next).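

In this assay, going by these compounds alone, a six-membered aromatic ring with a hetero atom and a hydrogen-bond donor replaces the carbon-only ring of the earlier compounds, giving a 1.0-fold higher number from compound 1 to compound 3 (0.01 log units; within the scatter) and a 1.2-fold lower number from compound 2 to compound 3 (0.07 log units; within the scatter). The earlier step changed only the groups on a carbon-only ring, whereas here the ring itself changes, and the number still stays within the scatter. No supporting data bear on why this position tolerates the exchange.

Going by these compounds, whether a carboxylic acid or a simple amine in place of the aromatic ring would move the number remains open. So does the effect of a longer chain between the sulfur and the shared core.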